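The compounds below may be only part of what the source reports. "The series", "measured", "known", "first", "only" and "open" are said of these compounds alone.

Compound 1 `Cc1cccc(CSc2cc(Cl)c(C)cc2S(=O)(=O)/N=C(\N)n2nccc2-c2ccccc2)c1` gives 47000 nM in a functional assay on MCF7 cells (Homo sapiens) for cytotoxicity, read by MTT assay, with a stated time of 72 h (a lower number here means a stronger inhibitor, a higher number a weaker inhibitor), and compound 2 `Cc1cc(S(=O)(=O)/N=C(\N)n2nccc2-c2ccccc2)c(SCc2cccc(Cl)c2)cc1Cl` gives 88000 nM in this assay. Among the measured compounds shown here, compound 2 has compound 1 as its only measured neighbour, and the step of a 1.9-fold higher number from compound 1 to compound 2 (0.27 log units; within the scatter) stays inside the scatter. Compound 3 `Cc1cc(S(=O)(=O)/N=C(\N)n2nccc2-c2ccccc2)c(SCc2ccccc2)cc1Cl` differs from compound 2 by hydrogen in place of chloro on an aromatic carbon. For the measured compounds named here, the only measured step touching this position is the one from compound 1 to compound 2, and it was small, so no change beyond the scatter is expected for compound 3, the estimated step being a 1.5-fold lower number from compound 2 to compound 3 (0.17 log units; within the scatter). Compound 3 is expected at 60000 nM, with a range from 25000 nM to 150000 nM.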

Compound 3, half-maximal inhibitory concentration: 20000 nM
Compound 3: the middle estimate sits 3.0-fold (0.48 log units) above what was measured; measured number below the stated range.
By their numbers in this assay, from the lowest: compound 3; then compounds 1 and 2 (each within the scatter of the next).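

In this assay, 3-chlorobenzyl to benzyl gives a 4.4-fold lower number from compound 2 to compound 3 (0.64 log units; beyond the scatter), and losing the methyl gives a 2.4-fold lower number from compound 1 to compound 3 (0.37 log units; beyond the scatter). Both steps lie beyond the scatter, whereas chloro and methyl could not be told apart, so among these three compounds the number at this position follows the presence of a substituent, not which of the two it is. Nothing measured explains this.

As far as these compounds go, whether fluoro, an amine or a carboxylic acid on this aromatic carbon would give a number near that of compound 3 at 20000 nM stays open.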